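Methoxy to trifluoromethoxy in a cell toxicity test

The compounds below may be only part of what the source reports. "The series", "measured", "known", "first", "only" and "open" are said of these compounds alone.

Compound 1 `COc1cccc2[nH]c(C(=O)N[C@@H](CC(C)C)C(=O)N[C@H](C=O)C[C@@H]3CCNC3=O)cc12`: > 200000 nM
Compound 2 `COc1cccc2[nH]c(C(=O)N[C@@H](CC(C)C)C(=O)N[C@H](C#N)C[C@@H]3CCCNC3=O)cc12`: > 200000 nM

Both entries come from a toxicity assay on A549 cells (Homo sapiens) for cytotoxicity, read by CellTiter-Glo; a lower number here means that less compound is tolerated, a higher number that more compound is tolerated. Compound 2 reads > 200000 nM, which is a limit of the assay and not a number. Compound 1 shares that position, as the limit of > 200000 nM in this assay, at which 2 of the 2 values shown sit, shows. Going by the values given here, the only measured step, a step that the two limits leave unreadable from compound 1 to compound 2, therefore gives no size to carry forward.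

Compound 3 `CC(C)C[C@H](NC(=O)c1cc2c(OC(F)(F)F)cccc2[nH]1)C(=O)N[C@H](C#N)C[C@@H]1CCCNC1=O` differs from compound 2 in one place: trifluoromethyl in place of methyl on an oxygen on an aromatic ring. Put simply, methoxy becomes trifluoromethoxy. Among the compounds with values here, no measured step covers this change, so the only guide is where the two measured compounds sit in this assay. No step beyond the usual scatter is expected, although a readable number somewhat lower on the scale remains possible. The expected step is a number no higher from compound 2 to compound 3 (the limit leaves the size open). The estimate for compound 3 is 200000 nM, within an expected range of 70000 nM to 200000 nM.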

Compound 3, half-maximal cytotoxic concentration: 90000 nM
The estimate for compound 3 lay 2.2-fold (0.35 log units) above the measured number; measured number inside the range.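

In this assay, trifluoromethyl in place of methyl on an oxygen on an aromatic ring gives an at least 2.2-fold lower number from compound 2 to compound 3 (0.34 log units; beyond the scatter), a step beyond the usual scatter. This shows that the position is not silent: a change in this one group is enough to move the compound onto the readable part of the scale, which the earlier pair could not show. Compound 3 is the only one of the three with a readable number, and the other two values are limits: the limit of > 200000 nM in this assay, at which 2 of the 3 values shown sit.

The compounds shown leave open whether the fluorine atoms themselves or simply a larger group on that oxygen goes with the lower number. A difluoromethoxy or an ethoxy group at the same place would help to separate these two readings.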